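The compounds below may be only part of what the source reports. "The series", "measured", "known", "first", "only" and "open" are said of these compounds alone.

Compound 1 `Cc1ccc(NC(=O)Nc2nc(Nc3ccccc3)cc(Sc3c[nH]c4ccccc34)n2)cc1`, compound 2 `O=C(Nc1ccc(Cl)cc1)Nc1nc(Sc2c[nH]c3ccccc23)cc(N2CCCC2)n1` and compound 3 `O=C(Nc1ccccc1)Nc1nc(Nc2ccccc2)cc(Sc2c[nH]c3ccccc23)n1` share one core and were tested in a functional assay on MDA-MB-231 cells (Homo sapiens) for inhibition, with a stated time of 72 h; a higher number here means a weaker inhibitor, a lower number a stronger inhibitor. In this assay compound 1 gives 13400 nM, compound 2 gives 5850 nM and compound 3 gives 35900 nM. Compound 3 therefore stands highest of the three numbers, with compound 1 nearest and compound 2 furthest from it. Compound 4 `O=C(Nc1ccccc1)Nc1nc(Sc2c[nH]c3ccccc23)cc(N2CCCC2)n1` arises from compound 3 through one change: pyrrolidin-1-yl in place of anilino on an aromatic carbon. For the measured compounds named here, the single step measured so far, a 2.7-fold higher number from compound 1 to compound 3 (0.43 log units; beyond the scatter), concerns a different group and does not directly bear on this change. Going by the values given here, compound 2 carries the same pyrrolidin-1-yl group as compound 4 and shows a much lower number than compound 3, although compound 2 also differs elsewhere, so no single step isolates the group. On that basis compound 4 is expected to give a number lower than compound 3, a step of about a 3.3-fold lower number from compound 3 to compound 4 (0.51 log units; beyond the scatter), beyond the scatter. Compound 4 is estimated at 11000 nM, within a range of 4000 nM to 30000 nM.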

Compound 4, half-maximal inhibitory concentration: 7890 nM
The estimate for compound 4 lay 1.4-fold (0.14 log units) above the measured number; measured number inside the range.
By their numbers in this assay, from the lowest: compounds 2, 4 and 1 (each within the scatter of the next, the first and the last beyond it); then compound 3.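

In this assay, for the compounds shown here, pyrrolidin-1-yl in place of anilino on the aromatic carbon next to the ring nitrogen gives a 4.6-fold lower number from compound 3 to compound 4 (0.66 log units; beyond the scatter), the first step that isolates this position and shows that the number there responds to the group it carries. With pyrrolidin-1-yl present, hydrogen in place of chloro gives a 1.3-fold higher number from compound 2 to compound 4 (0.13 log units; within the scatter), so this chloro has no effect that can be told from the scatter, and the low number of compound 2 can now be read as coming with the pyrrolidin-1-yl group. Nothing available gives a reason for either step. The compounds shown leave open whether piperidin-1-yl, morpholin-4-yl or dimethylamino at this position would match pyrrolidin-1-yl. On these data alone, it also remains open whether methyl on the aromatic carbon, which gave a 2.7-fold higher number from compound 1 to compound 3 (0.43 log units; beyond the scatter) when removed alongside anilino, would matter alongside pyrrolidin-1-yl.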